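A few compounds are considered here, and "the series" means these few. Any claim that something is new, unique, unknown or untested is made for them only; others in the source may bear on it.

Compound 1 `O=C(/C=C/c1cccc(OCc2ccccc2)c1)c1ccc(Cl)cc1Cl` and compound 2 `O=C(/C=C/c1cccc(OCc2ccccc2)c1)c1ccc(Cl)cc1` share one core and differ in a single substituent on an aromatic carbon. In an ADME assay on HEK293 cells (Homo sapiens) for cytotoxicity, read by MTT assay, with a stated time of 68 h (on this read-out lower numbers stand for stronger inhibition and higher numbers for weaker inhibition), compound 1 gives 24900 nM, while compound 2 gives 22800 nM. For the measured compounds named here, the only measured step, a 1.1-fold lower number from compound 1 to compound 2 (0.04 log units; within the scatter), lies within the scatter, so the two measured compounds cannot be told apart and compound 2 simply shares the level of the only other number at hand. Compound 3 `O=C(/C=C/c1cccc(OCc2ccccc2)c1)c1cccc(Br)c1` has not yet been measured. It differs from compound 2 by 3-bromophenyl in place of 4-chlorophenyl on a carbonyl carbon. Going by the values given here, no measured step touches this part of the molecule, and the one step that does exist stayed within the scatter, so nothing in the data points to a shift beyond the scatter in this assay. Compound 3 is therefore estimated at 23000 nM, with a range from 10000 nM to 50000 nM. This estimate amounts to an expected step of a 1.0-fold higher number from compound 2 to compound 3 (0.00 log units; within the scatter), within the scatter.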

Compound 3, half-maximal inhibitory concentration: 7100 nM
Compound 3: middle estimate off by 3.2-fold (0.51 log units), on the high side; the whole stated range lies above it.
By their numbers in this assay, from the lowest: compound 3; then compounds 2 and 1 (each within the scatter of the next).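

Swapping the aryl group on the carbonyl carbon moves the read-out in a way the earlier pair did not: in this assay the change of 4-chlorophenyl to 3-bromophenyl gives a 3.2-fold lower number from compound 2 to compound 3 (0.51 log units; beyond the scatter) and so passes the scatter, whereas removing a chloro between compound 1 and compound 2 did not. The same holds against the dichlorinated aryl group, with a 3.5-fold lower number from compound 1 to compound 3 (0.54 log units; beyond the scatter) when 3-bromophenyl replaces 2,4-dichlorophenyl. No measurement available here offers an explanation for this shift.

The compounds shown leave open whether the halogen itself or its place on the ring carries the step, which 3-chlorophenyl and 4-bromophenyl on the same carbonyl carbon would separate. They also leave open how this position would respond to an aryl group bearing no halogen, such as one with an amine or a carboxylic acid.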